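Amide in place of amine on the aryl side chain

The source may report more compounds than this note shows. Statements on the series, on what has been measured and on what is new or still open speak of the compounds shown alone.

Compound 1: `COc1ccc(CCCC(C)(C)C)c(N2CCC(COc3cccc(C(CC(=O)O)C4CC4)c3)CC2)c1` gives 11 nM in a functional assay on cells for agonist activity at Free fatty acid receptor 1 (Homo sapiens), read by FLIPR and calcium flux, with a stated time of 60 min; on this read-out lower numbers stand for an effect already at smaller amounts and higher numbers for an effect only at larger amounts of compound.
Compound 2: `COc1ccc(CN(C)CC(C)C)c(N2CCC(COc3cccc(C(CC(=O)O)C4CC4)c3)CC2)c1` gives 1000 nM in this assay.

Within the data shown here, of the two measured compounds, compound 2 stands at the higher number; the only neighbour, compound 1, lies far lower, and the step of a 91-fold higher number from compound 1 to compound 2 (1.96 log units; beyond the scatter) is the one measured change: an isobutyl(methyl)amino group took the place of the 3,3-dimethylbutyl chain on the carbon joined to the aromatic ring.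

Compound 3, `COc1ccc(C(=O)N(C)CC(C)(C)C)c(N2CCC(COc3cccc(C(CC(=O)O)C4CC4)c3)CC2)c1`, has not yet been measured. Relative to compound 2 it carries methyl(neopentyl)carbamoyl in place of (isobutyl(methyl)amino)methyl on an aromatic carbon. Among the measured compounds shown here, the entering group keeps a branched chain of similar size to the one compound 1 carries, but now attached through a carbonyl rather than through a saturated carbon, so neither measured compound is a close model. For the measured compounds named here, the one measured step bears on it indirectly: removing the amine of compound 2 seems likely to recover part, not all, of the loss seen in a 91-fold higher number from compound 1 to compound 2 (1.96 log units; beyond the scatter).

Compound 3 is therefore expected to give 120 nM (range 25 nM to 600 nM), an expected step of an 8.3-fold lower number from compound 2 to compound 3 (0.92 log units; beyond the scatter).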

Compound 3, half-maximal effective concentration: 100 nM
Beside the measured number, compound 3's estimate is 1.2-fold (0.08 log units) above it; low and high end bracket the measured number.
By their numbers in this assay, from the lowest: compound 1; then compound 3; then compound 2.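

In this assay, methyl(neopentyl)carbamoyl in place of (isobutyl(methyl)amino)methyl on this aromatic carbon gives a 10-fold lower number from compound 2 to compound 3 (1.00 log units; beyond the scatter), so this position does not penalise every side chain that carries nitrogen to the same degree. The recovery is only partial, however: the same group in place of 4,4-dimethylpentyl gives a 9.1-fold higher number from compound 1 to compound 3 (0.96 log units; beyond the scatter), which leaves the all-carbon chain of compound 1 ahead of both nitrogen-bearing side chains. The numbers show the size of these steps, but no measurement here gives the reason for them.

Going by these compounds, compound 3 differs from compound 2 in two ways at once, with a carbonyl in the link and a neopentyl end in place of an isobutyl end, so the share of the gain that belongs to each remains open. A methyl(isobutyl)carbamoyl group or a (methyl(neopentyl)amino)methyl group at this position would separate the two changes.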